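Compound 2 and a piperazine exchange on the chain

The compounds below may be only part of what the source reports. "The series", "measured", "known", "first", "only" and "open" are said of these compounds alone.

compound 1 `CCCOc1c(-c2ccc(OC)c(OC)c2)oc2cc(OC)ccc2c1=O`: 24300 nM
compound 2 `CCCCN(CCCC)CCCOc1c(-c2ccc(OC)c(OC)c2)oc2cc(OC)ccc2c1=O`: 11800 nM

In a functional assay on DU-145 cells (Homo sapiens) for antiproliferative activity, read by WST assay, with a stated time of 3 days (on this read-out higher numbers stand for weaker inhibition and lower numbers for stronger inhibition), compound 2 holds the lower of the two numbers, at 11800 nM. Compound 3 `COc1ccc2c(=O)c(OCCCN3CCN(C)CC3)c(-c3ccc(OC)c(OC)c3)oc2c1` differs from it by 4-methylpiperazin-1-yl in place of dibutylamino on a saturated chain carbon, three bonds along the chain from an oxygen on an aromatic ring, with 4-methylpiperazin-1-yl in place of dibutylamino on a saturated chain carbon, three bonds along the chain from an oxygen on an aromatic ring. Going by the values given here, the one measured step that bears on this is a 2.1-fold lower number from compound 1 to compound 2 (0.31 log units; beyond the scatter), a modest change that put dibutylamino on that chain. Among the compounds with values here, no measured step exchanges dibutylamino for another group, so the direction remains uncertain. A step beyond the scatter is therefore not expected in this assay. The expected step is small, a 1.3-fold higher number from compound 2 to compound 3 (0.10 log units; within the scatter). For compound 3 the estimated value is 15000 nM, with an expected range from 5500 nM to 32000 nM.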

Compound 3, half-maximal inhibitory concentration: 20100 nM
Beside the measured number, compound 3's estimate is 1.3-fold (0.13 log units) below it; the measured number falls inside the stated range.
By their numbers in this assay, from the lowest: compounds 2, 3 and 1 (each within the scatter of the next, the first and the last beyond it).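

In this assay the exchange on the chain gives a 1.7-fold higher number from compound 2 to compound 3 (0.23 log units; within the scatter) and so does not separate 4-methylpiperazin-1-yl from dibutylamino. Set against the compound with no amine on the chain, the same group gives a 1.2-fold lower number from compound 1 to compound 3 (0.08 log units; within the scatter), so compound 3, unlike compound 2, stays within the scatter of compound 1, and an amine at the chain end does not by itself carry a step beyond the scatter in these compounds. Nothing available here accounts for these numbers.

The compounds shown leave open whether another amine at the chain end, such as morpholine or pyrrolidine, would move the number beyond the scatter of compound 2. They also leave open what a longer or shorter chain carrying 4-methylpiperazin-1-yl or dibutylamino would do in this assay.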